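Benzyl to methyl on selenium in two acylselenourea pairs

The source may report more compounds than this note shows. Statements on the series, on what has been measured and on what is new or still open speak of the compounds shown alone.

The compounds in this set were examined in a functional assay on MCF7 cells (Homo sapiens) for cytotoxicity, read by MTT assay, with a stated time of 72 h; on this read-out lower numbers stand for stronger inhibition of growth and higher numbers for weaker inhibition of growth. Compound 1, `O=C(/N=C(/NC(=O)c1ccno1)[Se]Cc1ccccc1)c1ccno1`, carries a benzyl group on its selenium atom. In this assay compound 1 gives only the limit > 100000 nM, which is the ceiling of the assay rather than a measured number (the limit of > 100000 nM in this assay, at which 1 of the 3 values shown sits). Compound 2, `C[Se]/C(=N\C(=O)c1ccno1)NC(=O)c1ccno1`, is its methyl counterpart. In this assay compound 2 gives 57500 nM. The change between them is hydrogen in place of phenyl on a saturated chain carbon bound to a selenium atom, and on the read-out it produced an at least 1.7-fold lower number from compound 1 to compound 2 (0.24 log units; that floor lies within the scatter); because one end of that step is the limit (the limit of > 100000 nM in this assay, at which 1 of the 3 values shown sits), only a floor for its size is known.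

Compound 3, `O=C(/N=C(/NC(=O)c1csc([N+](=O)[O-])c1)[Se]Cc1ccccc1)c1csc([N+](=O)[O-])c1`, keeps the benzyl group on selenium but has a different core; the difference between the core of compound 1 and the core of compound 3 is not broken down here. In this assay compound 3 gives 54100 nM, a value that sits within the scatter of the number for compound 2.

Compound 4, `C[Se]/C(=N\C(=O)c1csc([N+](=O)[O-])c1)NC(=O)c1csc([N+](=O)[O-])c1`, has not yet been measured. It differs from compound 3 by hydrogen in place of phenyl on a saturated chain carbon bound to a selenium atom, the same change that separates compound 1 from compound 2, at the same place. Given that compound 3 already gives a number below the limit, the step is expected to be a 1.5-fold lower number from compound 3 to compound 4 (0.19 log units; within the scatter), a modest shift at most. Compound 4 is therefore estimated at 35000 nM in this assay, within a range from 12000 nM to 100000 nM.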

Compound 4, concentration for total growth inhibition: 28100 nM
For compound 4 the middle estimate is 1.2-fold (0.10 log units) above the measured one; the measured number falls inside the stated range.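

Carried onto the core of compound 3, the change from benzyl to methyl on selenium gives a 1.9-fold lower number from compound 3 to compound 4 (0.28 log units; within the scatter) in this assay, so this step stays within the usual scatter, as does the floor known for the earlier pair. The two pairs are compatible with one small shared step, but they do not show that the change has a real effect on either core, and they cannot settle whether its size is the same on both: the same change on two cores in this assay, an at least 1.7-fold lower number (0.24 log units; that floor lies within the scatter) from compound 1 to compound 2 and a 1.9-fold lower number (0.28 log units; within the scatter) from compound 3 to compound 4; the limit leaves it open whether they differ. As far as these compounds go, the true size of the step on the core of compound 1 remains unknown because compound 1 gives > 100000 nM, which is a limit and not a number: the limit of > 100000 nM in this assay, at which 1 of the 4 values shown sits.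

Only benzyl and methyl appear on selenium here, on two cores, which leaves open how an ethyl group, a longer chain or a benzyl group with a substituted phenyl would read in this assay. From the compounds shown here alone, it is also open whether a chain ending in an amine or a carboxylic acid at the same place would move the number beyond the scatter, and whether the step would look the same on further cores.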